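The source may report more compounds than this note shows. Statements on the series, on what has been measured and on what is new or still open speak of the compounds shown alone.

Measured compounds in the series:
- compound 1 `Cc1c(C(=O)Nc2nnn[nH]2)oc2ccccc2c1=O`: in a functional assay on cells (Mast cell, Rattus norvegicus) for inhibition, with a stated time of 15 min (on this read-out lower numbers stand for an effect already at smaller amounts and higher numbers for an effect only at larger amounts of compound), compound 1 gives 0.4 ug/mL
- compound 2 `Cn1nnnc1NC(=O)c1cc(=O)c2ccccc2o1`: in this assay compound 2 gives only the limit > 18 ug/mL, not a number

Among the measured compounds shown here, compound 1 therefore stands as the only numerical value in this assay so far. For the measured compounds named here, for compound 2 the record holds nothing beyond (the limit of > 18 ug/mL in this assay, at which 1 of the 2 values shown sits), so the two measured compounds are linked by no step, and what compound 2 shows can be said only as a limit.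

Compound 3 `O=C(Nc1nnn[nH]1)c1oc2ccccc2c(=O)c1Cl` is the next member to be measured. It differs from compound 1 in a single place: chloro in place of methyl on an aromatic carbon. Both the group that leaves and the group that enters are single heavy atoms without donors or acceptors, and the rest of the shared core of compound 1 is kept unchanged, including the amide and the tetrazole bearing the ring hydrogen that compound 2 lacks.

Going by the values given here, with no measured step of this kind available, the step from compound 1 to compound 3 is expected to fall within the usual scatter, in no set direction: no change at the digits printed from compound 1 to compound 3 (within the scatter). Compound 3 is accordingly estimated at 0.4 ug/mL in this assay, with a range of 0.1 ug/mL to 1.5 ug/mL.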

Compound 3, concentration for half-maximal effect: 0.8 ug/mL
For compound 3 the middle estimate is 2.0-fold (0.30 log units) below the measured one; measured number inside the range.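

In this assay, the aromatic carbon two atoms from the ring oxygen now has its first measured step: a 2.0-fold higher number from compound 1 to compound 3 (0.30 log units; within the scatter). Chloro in place of methyl therefore cannot be told apart from no change on this read-out, and with the rest of the shared core kept, both single-atom groups at this place give a number rather than a limit. No measured property among the data bears on this step, so the result stands as an observation on these two groups alone.

Among the compounds shown here, compound 2 remains a limit and not a number, and it differs from compound 1 in more than one place, so no step to it can be read: the limit of > 18 ug/mL in this assay, at which 1 of the 3 values shown sits. Open at this position is how the read-out responds to a group unlike methyl and chloro, such as an amine, a carboxylic acid or a longer chain, or to plain hydrogen, and two groups of one heavy atom each give no indication of how much larger a group the place would tolerate.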